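From phenyl to 4-methoxyphenoxy: expected cytotoxicity shift

The source may report more compounds than this note shows. Statements on the series, on what has been measured and on what is new or still open speak of the compounds shown alone.

Three compounds share one core and differ only in the group on one aromatic carbon. Compound 1 `c1ccc(Oc2ccc3c(NCCCNCc4ccco4)ccnc3c2)cc1` carries a phenoxy group and in an ADME assay on HepG2 cells (Homo sapiens) for cytotoxicity, read by luminescence, CellTiter-Glo and ATP content, with a stated time of 72 h (a lower number here means that less compound is needed, a higher number that more compound is needed for the effect), compound 1 gives 15200 nM. Compound 2 `Clc1ccc(Oc2ccc3c(NCCCNCc4ccco4)ccnc3c2)cc1` carries a 4-chlorophenoxy group, and compound 2 gives 7800 nM; the change from compound 1 is a 1.9-fold lower number from compound 1 to compound 2 (0.29 log units; within the scatter). Compound 3 `c1ccc(-c2ccc3c(NCCCNCc4ccco4)ccnc3c2)cc1` carries a phenyl group, and compound 3 gives 5920 nM, the lowest of the three numbers; the step was a 2.6-fold lower number from compound 1 to compound 3 (0.41 log units; beyond the scatter), while a 1.3-fold lower number from compound 2 to compound 3 (0.12 log units; within the scatter).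

Compound 4 `COc1ccc(Oc2ccc3c(NCCCNCc4ccco4)ccnc3c2)cc1` differs from compound 3 in this way: 4-methoxyphenoxy in place of phenyl on an aromatic carbon. This reverses the phenyl-for-phenoxy step, which on its own was modest, and adds a methoxy group to the phenoxy ring. The chloro addition in compound 2 stayed within the scatter, so the decoration of the phenoxy ring is not expected to matter much. The number for compound 4 is therefore expected to move back toward that of compound 1, an estimated 1.9-fold higher number from compound 3 to compound 4 (0.27 log units; within the scatter). Compound 4 is estimated at 11000 nM, with a range from 5000 nM to 25000 nM.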

Compound 4, half-maximal effective concentration: 5300 nM
The estimate for compound 4 lay 2.1-fold (0.32 log units) above the measured number, and the stated range covers the measured number.
By their numbers in this assay, from the lowest: compounds 4, 3, 2 and 1 (each within the scatter of the next, the first and the last beyond it).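

In this assay, the phenoxy linkage alone does not bring back the high number of compound 1, since the 4-methoxyphenoxy group and the phenyl group cannot be told apart at this position: a 1.1-fold lower number from compound 3 to compound 4 (0.05 log units; within the scatter). On the phenoxy ring, methoxy in place of chloro gives a 1.5-fold lower number from compound 2 to compound 4 (0.17 log units; within the scatter), while methoxy in place of hydrogen gives a 2.9-fold lower number from compound 1 to compound 4 (0.46 log units; beyond the scatter), so the substituent on that ring can matter, although the methoxy and chloro groups stay within the scatter of each other. No evidence is available to explain these numbers.

From the compounds shown here alone, it remains open whether an amine or a carboxylic acid on the phenoxy ring would give a similar number. Going by these compounds, it is also open whether a longer chain at this position would leave the number unchanged.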